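Aryloxyacetyl to arylpropanoyl exchange at the piperazine amide

The source may report more compounds than this note shows. Statements on the series, on what has been measured and on what is new or still open speak of the compounds shown alone.

Measured compounds, with the read-out in an assay on HEK293 cells for displacement of a labelled ligand from Melanocortin receptor 4 (Homo sapiens); a lower number here means a stronger inhibitor, a higher number a weaker inhibitor:
compound 1, `COc1ccc(OCC(=O)N2CCN(c3ccc(C(F)(F)F)cc3[C@@H](N)CC(C)C)CC2)cc1`: 3800 nM
compound 2, `Cc1ccc(OCC(=O)N2CCN(c3ccc(C(F)(F)F)cc3[C@@H](N)CC(C)C)CC2)cc1`: 4400 nM
compound 3, `CC(C)C[C@H](N)c1cc(C(F)(F)F)ccc1N1CCN(C(=O)COc2ccc(Cl)cc2)CC1`: 2900 nM

Compound 3 sits at the lowest of the three numbers, but the gaps are small: a 1.3-fold lower number from compound 1 to compound 3 (0.12 log units; within the scatter) and a 1.5-fold lower number from compound 2 to compound 3 (0.18 log units; within the scatter), both within the scatter, as is a 1.2-fold higher number from compound 1 to compound 2 (0.06 log units; within the scatter). So the three aryl substituents examined so far leave this assay essentially unmoved.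

Compound 4, `COc1ccc(CC(C)C(=O)N2CCN(c3ccc(C(F)(F)F)cc3[C@@H](N)CC(C)C)CC2)cc1`, is the next step: 1-(4-methoxybenzyl)ethyl in place of (4-chlorophenoxy)methyl on a carbonyl carbon. Two things change at once, the aryl substituent and the link between the aryl ring and the carbonyl. The first part has precedent: compound 1 carries the same methoxy on the aryl ring, and its gap to compound 3 is within the scatter. Within the data shown here, the second part, the branched carbon chain in place of the ether oxygen, has no counterpart among the measured compounds, so no step size can be read from them for it.

The expectation for compound 4 is therefore a number close to that of compound 3, a 1.2-fold higher number from compound 3 to compound 4 (0.08 log units; within the scatter), with no step beyond the scatter as the central case but a wide range to allow for the new linker. Compound 4 is estimated at 3500 nM in this assay, within 1200 nM to 12000 nM.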

Compound 4, inhibition constant: 120 nM
Compound 4: middle estimate off by 29-fold (1.46 log units), on the high side; the whole stated range lies above it.
By their numbers in this assay, from the lowest: compound 4; then compounds 3, 1 and 2 (each within the scatter of the next).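

In this assay, among these compounds, the group on the carbonyl carbon is the first place where a change goes beyond the scatter: the step of a 32-fold lower number from compound 1 to compound 4 (1.50 log units; beyond the scatter) keeps the methoxy on the aryl ring, so it reads the linker change alone, 1-(4-methoxybenzyl)ethyl in place of (4-methoxyphenoxy)methyl. The steps of a 37-fold lower number from compound 2 to compound 4 (1.56 log units; beyond the scatter) and a 24-fold lower number from compound 3 to compound 4 (1.38 log units; beyond the scatter) are also large, so the aryl substituents that made no difference among the aryloxyacetyl compounds do not account for this result. No supporting data bear on the reason for these steps.

Loss of the ether oxygen and gain of the branching methyl remain unseparated; the unbranched 2-(4-methoxyphenyl)ethyl group on the same carbonyl carbon would divide them. Also open, going by these compounds, is whether chloro or methyl in place of methoxy stays without effect on the new linker.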